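Replacing the 2-phenylethenyl group of compound 2

This account rests on a few compounds, and the source may have more. Where it says the series, first, only, none or still open, it means among the compounds named here.

In a physicochemical assay for lipophilicity, measured as octanol-water partition (a lower number here means a more polar compound, a higher number a more lipophilic compound), compound 1 (`O=C(NNc1ccnc2cc(Cl)ccc12)c1ccccc1/N=C/c1ccc(Cl)cc1`) gives 5.62 and compound 2 (`O=C(NNc1ccnc2cc(Cl)ccc12)c1ccccc1/N=C/C=C/c1ccccc1`) gives 5.54, so these two stand level within the scatter. Compound 3 (`O=C(NNc1ccnc2cc(Cl)ccc12)c1ccccc1/N=C/c1cc2ccccc2[nH]c1=O`) differs from compound 2 as follows: a group of 11 heavy atoms (9 carbon, 1 nitrogen, 1 oxygen; one six-membered aromatic ring of carbon only, one six-membered aromatic ring with 1 hetero atom) in place of a group of 8 heavy atoms (8 carbon; one six-membered aromatic ring of carbon only), on a carbon with a double bond to nitrogen. Going by the values given here, the only measured step, a number 0.08 log units lower from compound 1 to compound 2 (within the scatter), exchanged groups without a ring containing a hetero atom, so it offers limited guidance here. The entering group brings nitrogen and oxygen, so a clearly lower number is expected in this assay. The expected step is a number 0.64 log units lower from compound 2 to compound 3 (beyond the scatter). Compound 3 is estimated at 4.9, with an expected range from 4.3 to 5.5.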

Compound 3, partition coefficient: 4.65
Compound 3: middle estimate off by 0.25 log units, on the high side, and the stated range covers the measured number.
By their numbers in this assay, from the lowest: compound 3; then compounds 2 and 1 (each within the scatter of the next).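

In this assay, the place on a carbon with a double bond to nitrogen now proves able to shift the number: the new group gives a number 0.89 log units lower from compound 2 to compound 3 (beyond the scatter) and also a number 0.97 log units lower from compound 1 to compound 3 (beyond the scatter), whereas the earlier exchange stayed within the scatter. Compared with 2-phenylethenyl, the entering group adds a ring with a hetero atom, a hydrogen-bond donor and a hydrogen-bond acceptor, and this single step cannot separate their contributions. No measurement shown explains the step.

Which of these features matters remains open. So does how an amine or a carboxylic acid at this place would compare.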